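Adding a Pyridinylmethyl Arm to Compound 3

A few compounds are considered here, and "the series" means these few. Any claim that something is new, unique, unknown or untested is made for them only; others in the source may bear on it.

Of the compounds shown here, three built on one shared core have been measured in a physicochemical assay for solubility; on this read-out lower numbers stand for lower solubility and higher numbers for higher solubility. Compound 1 `CCn1c(=O)n(-c2ccc(C#N)c(C(F)(F)F)c2)c2ccccc21` gives 3470 nM. Compound 2 `N#Cc1ccc(-n2c(=O)n(Cc3cccnc3)c3ccccc32)cc1C(F)(F)F` gives 2500 nM. Compound 3 `N#Cc1ccc(-n2c(=O)[nH]c3ccccc32)cc1C(F)(F)F`, which carries only a hydrogen on its ring nitrogen, gives 7900 nM and stands highest of the three numbers. The steps that lead to it are a 2.3-fold higher number from compound 1 to compound 3 (0.36 log units; beyond the scatter) and a 3.2-fold higher number from compound 2 to compound 3 (0.50 log units; beyond the scatter), while between the two substituted compounds there is a 1.4-fold lower number from compound 1 to compound 2 (0.14 log units; within the scatter).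

Compound 4 `N#Cc1ccc(-n2c(=O)n(Cc3ccccn3)c3ccccc32)cc1C(F)(F)F` differs from compound 3 by (pyridin-2-yl)methyl in place of hydrogen on an aromatic nitrogen. This reverses the kind of change seen in the steps from compound 1 and compound 2 to compound 3, where removing a group from the ring nitrogen raised the number modestly. Adding a group back is therefore expected to lower the number modestly in this assay, as a 2.9-fold lower number from compound 3 to compound 4 (0.47 log units; beyond the scatter). Compound 4 is expected to give about 2700 nM, with a likely range from 1300 nM to 5500 nM.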

Compound 4, solubility: 12000 nM
For compound 4 the middle estimate is 4.4-fold (0.65 log units) below the measured one; the measured number lies above the stated range.
By their numbers in this assay, from the lowest: compounds 2 and 1 (each within the scatter of the next); then compounds 3 and 4 (each within the scatter of the next).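

In this assay, a (pyridin-2-yl)methyl arm on the aromatic nitrogen leaves the number level with that of the hydrogen-bearing compound (a 1.5-fold higher number from compound 3 to compound 4 (0.18 log units; within the scatter)), so adding a group at this position does not always lower the number. The place of the nitrogen within the pyridine ring also counts here: pyridin-2-yl in place of pyridin-3-yl gives a 4.8-fold higher number from compound 2 to compound 4 (0.68 log units; beyond the scatter) and pyridin-2-yl in place of methyl gives a 3.5-fold higher number from compound 1 to compound 4 (0.54 log units; beyond the scatter), which makes compound 4 the exception to the lower numbers seen for compound 1 and compound 2. Nothing available explains why these two pyridine arms differ.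

The compounds shown leave open where a (pyridin-4-yl)methyl arm or a plain phenylmethyl arm would fall. They also leave open whether a longer chain carrying the pyridin-2-yl ring would stay level with compound 4.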